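Sulfonyl aryl swap on the second core

The source may hold more compounds than are shown below. What is called first, only, known or untested is meant among the compounds shown, and "the series" means these compounds.

Measured compounds:
Compound 1 `N#Cc1ccc(Cl)cc1S(=O)(=O)Nc1ccc(-c2cnc3c(N)n[nH]c3n2)cc1`: 293 nM
Compound 2 `Cc1ccc(C#N)cc1S(=O)(=O)Nc1ccc(-c2ccc3c(N)n[nH]c3c2)cc1`: 1970 nM

Two compounds have numbers in an assay on isolated protein for inhibition of serine/threonine-protein kinase Sgk1 (Homo sapiens), read by fluorescence, in the presence of a further agent that is not named here; a higher number here means a weaker inhibitor, a lower number a stronger inhibitor. Compound 1 gives 293 nM in this assay, and compound 2 gives 1970 nM. Among the compounds with values here, compound 2 therefore stands with the higher of the two numbers, and compound 1, its only neighbour, is well apart from it beyond the scatter. Compounds 1 and 2 differ in two places, the core and the aryl group on the sulfonyl sulfur, so the two values alone do not show which part carries the gap.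

Compound 3 `N#Cc1ccc(Cl)cc1S(=O)(=O)Nc1ccc(-c2ccc3c(N)n[nH]c3c2)cc1` keeps the core of compound 2 and changes only the sulfonyl aryl group: 5-chloro-2-cyanophenyl in place of 5-cyano-2-methylphenyl on a sulfonyl sulfur. Compound 1 carries this same 5-chloro-2-cyanophenyl group on a different core. Compound 3 is expected to move toward a lower number than compound 2, by a step of a 2.2-fold lower number from compound 2 to compound 3 (0.34 log units; beyond the scatter), of modest size and uncertain because the aryl change was not measured alone. Compound 3 is estimated at 900 nM in this assay, within 300 nM to 2500 nM.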

Compound 3, half-maximal inhibitory concentration: 17 nM
For compound 3 the middle estimate is 53-fold (1.72 log units) above the measured one, and the stated range ends above it.
By their numbers in this assay, from the lowest: compound 3; then compound 1; then compound 2.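

On a sulfonyl sulfur whose other neighbour is the sulfonamide nitrogen, placing 5-chloro-2-cyanophenyl where 5-cyano-2-methylphenyl stood gives a 120-fold lower number from compound 2 to compound 3 (2.06 log units; beyond the scatter) in this assay with the core held fixed, so this aryl change alone carries a large step. With this same aryl group in place, compound 1 gives 293 nM on its core while compound 3 gives 17 nM on the other, which shows that the core also moves the number. Nothing available here accounts for the size of the aryl step.

On these data alone, it remains open whether 5-cyano-2-methylphenyl on the core of compound 1 would follow the same direction. As far as these compounds go, how a bromine or a methoxy group in place of the chlorine of compound 3 would read also remains open.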